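The source may hold more compounds than are shown below. What is called first, only, known or untested is meant among the compounds shown, and "the series" means these compounds.

Working notes on the series, all sharing one core. In a functional assay on HL-60 cells (Homo sapiens) for inhibition (a lower number here means a stronger inhibitor, a higher number a weaker inhibitor), compound 1 (`COc1ccc(-c2cc(=O)n(Cc3cccnc3)nc2-c2ccc(OC)cc2)cc1`) gives 430 nM, compound 2 (`COc1ccc(-c2cc(=O)n(C)nc2-c2ccc(OC)cc2)cc1`) gives 1130 nM and compound 3 (`COc1ccc(-c2cc(=O)n(CC3CC3)nc2-c2ccc(OC)cc2)cc1`) gives 1800 nM. Compound 3 therefore sits with the higher pair of numbers: a 1.6-fold higher number from compound 2 to compound 3 (0.20 log units; within the scatter), while a 4.2-fold higher number from compound 1 to compound 3 (0.62 log units; beyond the scatter), and that second gap lies beyond the scatter.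

Compound 4 (`COc1ccc(-c2cc(=O)n(C3CCCC3)nc2-c2ccc(OC)cc2)cc1`) carries cyclopentyl in place of cyclopropylmethyl on an aromatic nitrogen. The closest evidence is the pair without pyridin-3-yl, compounds 2 and 3, whose step stays within the scatter. Compound 1 goes against any flat picture, as a 2.6-fold higher number from compound 1 to compound 2 (0.42 log units; beyond the scatter) is a modest step beyond the scatter, but compound 4 has no pyridin-3-yl. Among the measured compounds shown here, no measured compound carries a substituent joined directly through a ring carbon, so the estimate stays loose. The expected shift is a 1.2-fold lower number from compound 3 to compound 4 (0.08 log units; within the scatter), which is no change beyond the scatter in this assay. For compound 4 the estimated value is 1500 nM, with an expected range of 600 nM to 4000 nM.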

Compound 4, half-maximal inhibitory concentration: 510 nM
Compound 4: the middle estimate sits 2.9-fold (0.47 log units) above what was measured; measured number outside the range, below it.
By their numbers in this assay, from the lowest: compounds 1 and 4 (each within the scatter of the next); then compounds 2 and 3 (each within the scatter of the next).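

On the aromatic nitrogen, a substituent joined directly through a ring carbon gives the first clear move among the purely carbon groups in this assay: there is a 3.5-fold lower number from compound 3 to compound 4 (0.55 log units; beyond the scatter) and a 2.2-fold lower number from compound 2 to compound 4 (0.35 log units; beyond the scatter), so the flat picture from methyl and cyclopropylmethyl does not hold for every such group at this position. Pyridin-3-yl is also not required to reach the low end of these numbers, as there is only a 1.2-fold higher number from compound 1 to compound 4 (0.07 log units; within the scatter) and cyclopentyl cannot be told apart from (pyridin-3-yl)methyl here. No measurement at hand accounts for the difference between cyclopentyl and cyclopropylmethyl.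

Cyclopentyl differs from cyclopropylmethyl in both ring size and attachment, and these two changes stay unseparated; cyclopropyl or cyclohexyl joined directly to the nitrogen would address this. Benzyl, with a plain phenyl ring on the same chain carbon, would show whether the pyridine nitrogen matters at all.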